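Swapping the benzyl substituent for a cyclohexylmethyl group

The source may report more compounds than this note shows. Statements on the series, on what has been measured and on what is new or still open speak of the compounds shown alone.

Of the compounds shown here, two have been measured so far. Compound 1 `CN(C)CCN1CCN(c2nc(-c3ccccn3)nc3c2CN(Cc2ccccc2)CC3)CC1` gives 1500 nM in an assay on FRT cells with Cystic fibrosis transmembrane conductance regulator variant F508del (Homo sapiens) as the target, read by fluorescence, with a stated time of 25 min; a higher number here means that more compound is needed for the effect, a lower number that less compound is needed. Compound 2 `CC(C)c1ccc(CN2CCc3nc(-c4ccccn4)nc(N4CCN(CCN(C)C)CC4)c3C2)cc1` gives 300 nM in this assay, the lowest of the two numbers shown; the only change on the way there was a 5.0-fold lower number from compound 1 to compound 2 (0.70 log units; beyond the scatter).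

Compound 3 `CN(C)CCN1CCN(c2nc(-c3ccccn3)nc3c2CN(CC2CCCCC2)CC3)CC1` carries a different substituent on the same position: cyclohexyl in place of 4-isopropylphenyl on a saturated chain carbon bound to an amine nitrogen in a ring. This change takes away both the aromatic ring and the isopropyl group whose arrival marked the step from compound 1 to compound 2, and puts a saturated ring in their place. Among the compounds with values here, no measured pair shows directly what the exchange of an aromatic ring for a saturated one does here, so the expectation rests on the one step that exists: because the step of a 5.0-fold lower number from compound 1 to compound 2 (0.70 log units; beyond the scatter) showed that removing the isopropyl group from compound 1 costs ground, compound 3 is expected to move back toward the number of compound 1, giving an expected step of a 3.3-fold higher number from compound 2 to compound 3 (0.52 log units; beyond the scatter). The estimated value for compound 3 in this assay is therefore 1000 nM, with a likely range from 300 nM to 4000 nM.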

Compound 3, half-maximal effective concentration: 900 nM
Beside the measured number, compound 3's estimate is 1.1-fold (0.05 log units) above it, within the range that was stated.
By their numbers in this assay, from the lowest: compound 2; then compounds 3 and 1 (each within the scatter of the next).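

Phenyl and cyclohexyl can now be compared directly at this position in this assay: the exchange gives a 1.7-fold lower number from compound 1 to compound 3 (0.22 log units; within the scatter) and so leaves the number within the scatter, which means that in this one pair an aromatic ring is not needed to hold the level of compound 1. The cyclohexylmethyl group does not match the 4-isopropylbenzyl group, with a 3.0-fold higher number from compound 2 to compound 3 (0.48 log units; beyond the scatter) as the cost of that exchange, so among these three compounds only compound 2 stands apart from the others. No supporting measurement is available to explain why the numbers fall this way.

Compound 2 differs from compound 3 in both the ring and the isopropyl group, so these compounds do not show which of the two matters more. A cyclohexyl ring carrying an isopropyl group would address that question, while a tert-butyl group on the phenyl ring or a longer chain leading to the ring would show how far this position tolerates other shapes.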